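The source may hold more compounds than are shown below. What is called first, only, known or untested is meant among the compounds shown, and "the series" means these compounds.

Compound 1 `C[C@]1(CN2CCc3nc(C(F)(F)F)ccc3C2)Cn2cc([N+](=O)[O-])nc2O1`: in an ADME assay on Vero cells (Chlorocebus sabaeus) for cytotoxicity, read by MTT assay, with a stated time of 72 h (on this read-out higher numbers stand for lower toxicity in this test and lower numbers for higher toxicity in this test), compound 1 gives "not determined" (no result reported).
Compound 2 `C[C@]1(CN2CCc3nc(-c4cccc(Cl)c4F)ccc3C2)Cn2cc([N+](=O)[O-])nc2O1`: compound 2 gives > 32 ug/mL, which is a limit of the test.
Compound 3 `C[C@]1(CN2CCc3nc(-c4ccc(Cl)cc4F)ccc3C2)Cn2cc([N+](=O)[O-])nc2O1`: compound 3 gives > 32 ug/mL, likewise a limit.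

Compound 3 thus stands at the limit of this assay, and compound 2 stands there as well, both at the limit of > 32 ug/mL in this assay, at which 2 of the 3 values shown sit, while compound 1 carries no result. Going by the values given here, the single step among the measured compounds, a step that the two limits leave unreadable from compound 2 to compound 3, cannot be read for that reason. Compound 4 `C[C@]1(CN2CCc3nc(-c4cc(F)c(F)c(F)c4)ccc3C2)Cn2cc([N+](=O)[O-])nc2O1` differs from compound 3 by 3,4,5-trifluorophenyl in place of 4-chloro-2-fluorophenyl on an aromatic carbon. Among the compounds with values here, no measured step shows how such a change moves this assay, so the expectation is for no step beyond the scatter and, most likely, another value that only reaches the limit. Compound 4 is estimated at 40 ug/mL, with a range from 16 ug/mL to 100 ug/mL, an expected step that the limit leaves unreadable from compound 3 to compound 4.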

Compound 4, half-maximal cytotoxic concentration: > 32 ug/mL
Compound 4: a limit, no number; the forecaster's own chance of this, stated with the estimate: 70%; the middle value is on the limit's open side.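

Going by these compounds alone, compound 2, compound 3 and compound 4 each give only a limit in this assay, so no step among them can be read. The compounds shown leave open at what concentration any of them becomes toxic, and how their substituted phenyl groups compare.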